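The compounds below may be only part of what the source reports. "The series", "measured", "known", "first", "only" and "open" are said of these compounds alone.

In an assay on cells with melanin-concentrating hormone receptor 1 (Homo sapiens) as the target, read by radioligand binding (a lower number here means a stronger inhibitor, a higher number a weaker inhibitor), compound 1 `CCC(C)COc1cccc2ccc(N)nc12` gives 36 nM, the lower of the two numbers recorded for this set. Compound 3 `CNc1ccc2cccc(OC(C)CC(C)(C)C)c2n1` gives 310 nM in this assay. Compound 2 `CC(CC(C)(C)C)Oc1cccc2ccc(N(C)C)nc12` returns only a limit in this assay, > 2000 nM, which is the limit of > 2000 nM in this assay, at which 1 of the 3 values shown sits. Within the data shown here, the single step measured between two compounds differing in one place runs an at least 6.4-fold lower number from compound 2 to compound 3 (0.80 log units; beyond the scatter), a change on the nitrogen of the shared core rather than on the ether side chain.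

Compound 4 `COCCOCCOc1cccc2ccc(N)nc12` has not yet been measured in this assay. It differs from compound 1 thus: (2-methoxyethoxy)methyl in place of sec-butyl on a saturated chain carbon bound to an oxygen on an aromatic ring. Among the measured compounds shown here, none of the measured steps touches the chain bound to the oxygen on the aromatic ring, so neither the size nor the direction of this step is anchored by the three known compounds; compound 4 does keep the unsubstituted amino nitrogen of compound 1. The expected value for compound 4 is 150 nM, with a range from 30 nM to 800 nM in this assay. That estimate corresponds to an expected step of a 4.2-fold higher number from compound 1 to compound 4 (0.62 log units; beyond the scatter).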

Compound 4, half-maximal inhibitory concentration: > 2000 nM
Compound 4 was reported as a limit; the forecaster's own chance of this, stated with the estimate: 10%; at least 13-fold (1.12 log units) between middle value and limit.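

In this assay, the chain on the oxygen proves to matter a great deal: (2-methoxyethoxy)methyl in place of sec-butyl gives an at least 55-fold higher number from compound 1 to compound 4 (1.74 log units; beyond the scatter), even though the unsubstituted amino nitrogen of compound 1 is kept. Among these compounds, no earlier step touched this position, so this is the first sign that a change here alone can cost so much. Compound 4 gives a limit and not a number, so the full size of the step stays unknown, and compound 4 now sits at the same limit as compound 2: the limit of > 2000 nM in this assay, at which 2 of the 4 values shown sit.

Whether a hexyl chain, made of carbon only, would hold the value of compound 1 stays open, so the compounds shown do not separate the oxygens of the entering chain from its length. Going by these compounds, how a chain ending in an amine would read also remains open.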